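The source may hold more compounds than are shown below. What is called first, only, known or untested is meant among the compounds shown, and "the series" means these compounds.

Within the data shown here, compound 2 `Clc1ccc(-c2nc(N3CCCCC3)c3nc[nH]c3n2)cc1` is one of two compounds measured in an assay on cells for displacement of a labelled ligand from adenosine receptor A3 (Homo sapiens), read by scintillation counting and radioligand binding, with a stated time of 180 min (a higher number here means a weaker inhibitor, a lower number a stronger inhibitor), and in that assay compound 2 gives 7.94 nM. The other, compound 1 `Clc1ccc(-c2nc(N3CCCCC3)c3nc[nH]c3n2)cc1Cl`, carries an additional chloro on the same aromatic ring, and in this assay compound 1 gives 79.4 nM. The single measured step is a 10-fold lower number from compound 1 to compound 2 (1.00 log units; beyond the scatter), so among these two numbers compound 2 stands lowest.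

Compound 3 `Oc1cccc(-c2nc(N3CCCCC3)c3nc[nH]c3n2)c1` has not been measured. It differs from compound 2 by 3-hydroxyphenyl in place of 4-chlorophenyl on an aromatic carbon. Part of this change resembles the measured step, in that a chloro on that aromatic ring leaves, and that step gave a 10-fold lower number from compound 1 to compound 2 (1.00 log units; beyond the scatter). The remainder, the entering hydroxyl, has no measured counterpart among these compounds, so no step bears on it directly. The expectation therefore rests on one step only, and the estimated step for this assay is a 3.8-fold higher number from compound 2 to compound 3 (0.58 log units; beyond the scatter), a modest rise in the number with wide uncertainty. On that basis compound 3 is expected to give about 30 nM, with a range from 5 nM to 200 nM.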

Compound 3, inhibition constant: 63.1 nM
The estimate for compound 3 lay 2.1-fold (0.32 log units) below the measured number; the measured number falls inside the stated range.
By their numbers in this assay, from the lowest: compound 2; then compounds 3 and 1 (each within the scatter of the next).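

In this assay, 3-hydroxyphenyl in place of 4-chlorophenyl, on the aromatic carbon between two ring nitrogen atoms, gives a 7.9-fold higher number from compound 2 to compound 3 (0.90 log units; beyond the scatter). The earlier compounds shown here showed only that taking one chloro off this aryl ring gives a 10-fold lower number from compound 1 to compound 2 (1.00 log units; beyond the scatter), whereas this result shows that a further change to the same ring can raise the number again, so the lower number of compound 2 does not hold across every substitution of that ring. No measurement shown here explains the rise.

The change removes the chloro, brings in a hydroxyl and alters the ring position of the substituent all at once, so the compounds shown cannot assign the rise to any one of these. Unsubstituted phenyl and 4-hydroxyphenyl at this carbon would begin to separate those parts, while 3-methoxyphenyl and 3-aminophenyl would test whether the hydroxyl itself matters, and the piperidin-1-yl group stays the same throughout, leaving its contribution open as well.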